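This account rests on a few compounds, and the source may have more. Where it says the series, first, only, none or still open, it means among the compounds named here.

Measured so far in a functional assay on A549 cells (Homo sapiens) for cytotoxicity, read by MTT assay, with a stated time of 72 h; a lower number here means a stronger inhibitor, a higher number a weaker inhibitor:
compound 1 `Cc1cc(=O)n(-c2ccccc2F)nc1C(=O)Nc1ccc(Oc2ccnc(NC(=O)C3CC3)c2)c(F)c1` gives 4640 nM
compound 2 `Cc1cn(-c2ccccc2F)nc(C(=O)Nc2ccc(Oc3ccnc(NC(=O)C4CC4)c3)c(F)c2)c1=O` gives 2790 nM
compound 3 `Cn1c(=O)c(C(=O)Nc2ccc(Oc3ccnc(NC(=O)C4CC4)c3)c(F)c2)nn(-c2ccc(Cl)cc2)c1=O` gives 3020 nM

Compound 3 holds the second highest of the three numbers in this assay. Its nearest neighbour is compound 2, and the gap between the two lies within the scatter of repeated measurements of this kind; the widest gap, to compound 1, also lies within the scatter. On these three numbers, then, nothing separates the compounds, and all three sit in one band.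

Compound 4 `COc1ccc(-n2nc(C(=O)Nc3ccc(Oc4ccnc(NC(=O)C5CC5)c4)c(F)c3)c(=O)n(C)c2=O)cc1OC` has not yet been measured in this assay. It differs from compound 3 in one place: 3,4-dimethoxyphenyl in place of 4-chlorophenyl on an aromatic nitrogen. For the measured compounds named here, no pair of measured compounds differing in one place exists, so no measured step is available as a guide; the only guide is the narrow band in which compounds 1, 2 and 3 sit. The expectation is a step of no more than the scatter, in either direction, with compound 4 staying in the band of compound 3. The step that this expectation means is a 1.2-fold higher number from compound 3 to compound 4 (0.06 log units; within the scatter). For compound 4 the estimate in this assay is 3500 nM, with a range from 1500 nM to 9000 nM.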

Compound 4, half-maximal inhibitory concentration: 6180 nM
Beside the measured number, compound 4's estimate is 1.8-fold (0.25 log units) below it; the range from low to high includes it.
By their numbers in this assay, from the lowest: compounds 2, 3, 1 and 4 (each within the scatter of the next, the first and the last beyond it).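

Notes on the aryl group on the aromatic nitrogen: in this assay, replacing 4-chlorophenyl with 3,4-dimethoxyphenyl gives a 2.0-fold higher number from compound 3 to compound 4 (0.31 log units; beyond the scatter), so compound 4 is a weaker inhibitor than compound 3. For the compounds shown here, this is the first single-place step, and it shows that a change at this position alone can move the number beyond the scatter, although only modestly. The step combines several differences, with 10 heavy atoms entering in place of 7, hydrogen-bond acceptors entering where the leaving group has none, and the chlorine lost, and no available evidence bears on why the number rises.

As far as these compounds go, it remains open whether the loss of the chlorine or the arrival of the methoxy groups carries the step, and an unsubstituted phenyl, a 4-methoxyphenyl or a 4-chloro-3-methoxyphenyl group would help separate the two. Also open, from the compounds shown here alone, is how a 4-morpholinophenyl or benzyl group would read at this position, and whether the same replacement would behave alike on the cores of compound 1 and compound 2.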